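Shortening the Pentylcarbonyl Chain of Compound 2

The source may report more compounds than this note shows. Statements on the series, on what has been measured and on what is new or still open speak of the compounds shown alone.

compound 1 (`CC(=O)NCC(=O)Nc1ccc(Cl)cc1C(=O)c1ccccc1`) : 37 mg/kg
compound 2 (`CCCCCC(=O)NCC(=O)N(C)c1ccc(Cl)cc1C(=O)c1ccccc1Cl`) : 1.9 mg/kg
compound 3 (`NCC(=O)NCC(=O)Nc1ccc([N+](=O)[O-])cc1C(=O)c1ccccc1`) : 4.82 mg/kg

In a functional assay on the whole organism for antagonist activity, with Mus musculus as the target (on this read-out higher numbers stand for an effect only at larger amounts of compound and lower numbers for an effect already at smaller amounts), compound 2 gives the lowest of the three numbers (1.9 mg/kg). Compound 3 stands nearest (4.82 mg/kg) and compound 1 furthest (37 mg/kg), both beyond the scatter. Compound 4 (`CC(=O)NCC(=O)N(C)c1ccc(Cl)cc1C(=O)c1ccccc1Cl`) follows from compound 2 by one change (hydrogen in place of butyl on a saturated chain carbon bound to a carbonyl carbon), hydrogen in place of butyl on a saturated chain carbon bound to a carbonyl carbon, which reads pentylcarbonyl to acetyl. Among the compounds with values here, no measured pair isolates this change. Compound 1 also carries acetamido and has the highest number (37 mg/kg), though it differs from compound 2 elsewhere too. A moderate rise beyond the scatter is therefore expected in this assay, and the estimated step is the following (a 3.2-fold higher number from compound 2 to compound 4 (0.50 log units; beyond the scatter)). Compound 4 is estimated at (6 mg/kg), within an expected range of (2 mg/kg) to (20 mg/kg).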

Compound 4, dose for half-maximal effect: 2.3 mg/kg
Compound 4: the middle estimate sits 2.6-fold (0.42 log units) above what was measured; the range from low to high includes it.
By their numbers in this assay, from the lowest: compounds 2 and 4 (each within the scatter of the next); then compound 3; then compound 1.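

In this assay the exchange of butyl for hydrogen on a saturated chain carbon bound to a carbonyl carbon gives a 1.2-fold higher number from compound 2 to compound 4 (0.08 log units; within the scatter) and so stays within the scatter. Within the data shown here, this pair is the first to isolate a change at this position, and on this core pentylcarbonyl and acetyl are not told apart. No data at hand bear on the reason for this result.

As far as these compounds go, whether an amine, a carboxylic acid or a chain longer than pentyl at this place would also stay within the scatter remains open. So does whether the same change would read alike on the core of compound 3.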